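Cytotoxicity at the Assay Limit Across an Aryl Series

The source may hold more compounds than are shown below. What is called first, only, known or untested is meant among the compounds shown, and "the series" means these compounds.

Three esters of a shared core, compound 1 `C/C(=C\CC/C(C)=C/CC[C@@H]1[C@@]2(C)CCC(=O)C(C)(C)[C@H]2CC[C@@]1(C)O)CC/C=C(\C)C(=O)OCc1cn(-c2ccccc2C)nn1`, compound 2 `C/C(=C\CC/C(C)=C/CC[C@@H]1[C@@]2(C)CCC(=O)C(C)(C)[C@H]2CC[C@@]1(C)O)CC/C=C(\C)C(=O)OCc1cn(-c2ccc(C(F)(F)F)cc2)nn1` and compound 3 `C/C(=C\CC/C(C)=C/CC[C@@H]1[C@@]2(C)CCC(=O)C(C)(C)[C@H]2CC[C@@]1(C)O)CC/C=C(\C)C(=O)OCc1cn(-c2ccc(F)cc2)nn1`, differ only in the group carried on an aromatic nitrogen. In an ADME assay on L132 cells (Homo sapiens) for cytotoxicity, read by MTT assay, with a stated time of 48 h (on this read-out higher numbers stand for weaker inhibition and lower numbers for stronger inhibition), compound 1 gives > 150000 nM, which is a limit of the assay rather than a number. In this assay compound 2 gives > 150000 nM, again a limit. In this assay compound 3 likewise gives > 150000 nM, also a limit. Because all three values sit at the limit of > 150000 nM in this assay, at which 3 of the 3 values shown sit, none of the steps between them can be read: a step that the two limits leave unreadable from compound 1 to compound 2, a step that the two limits leave unreadable from compound 1 to compound 3 and a step that the two limits leave unreadable from compound 2 to compound 3. Compound 2 therefore stands only at a limit, and the two further values shown are limits as well.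

Compound 4 `C/C(=C\CC/C(C)=C/CC[C@@H]1[C@@]2(C)CCC(=O)C(C)(C)[C@H]2CC[C@@]1(C)O)CC/C=C(\C)C(=O)OCc1cn(-c2ccc(C(C)(C)C)cc2)nn1` differs from compound 2 by tert-butyl in place of trifluoromethyl on an aromatic carbon. The step that bears most directly on this exchange is a step that the two limits leave unreadable from compound 2 to compound 3, which also replaces the group on the same aromatic carbon, yet its size is not readable. For the measured compounds named here, no measured step gives a direction for the change. In this assay compound 4 is therefore expected to give 200000 nM, with an expected range from 100000 nM to 500000 nM. The expected step is a step that the limit leaves unreadable from compound 2 to compound 4, and the result is most likely again reported only as a limit.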

Compound 4, half-maximal inhibitory concentration: 65800 nM
For compound 4 the middle estimate is 3.0-fold (0.48 log units) above the measured one, and the stated range ends above it.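

With tert-butyl on this aromatic carbon, the series gives its first readable step in this assay, and it points toward stronger inhibition: an at least 2.2-fold lower number from compound 2 to compound 4 (0.35 log units; beyond the scatter). The picture is the same when tert-butyl is set against fluoro, with an at least 2.2-fold lower number from compound 3 to compound 4 (0.35 log units; beyond the scatter), and when the whole 4-(tert-butyl)phenyl group is set against 2-methylphenyl on the aromatic nitrogen, with an at least 2.2-fold lower number from compound 1 to compound 4 (0.35 log units; beyond the scatter). Trifluoromethyl and tert-butyl have the same heavy-atom count and neither has a hydrogen-bond donor or acceptor, so these counts do not separate compound 2 from compound 4, and each step gives only a minimum size since the other three values are limits: the limit of > 150000 nM in this assay, at which 3 of the 4 values shown sit.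

As far as these compounds go, whether an isopropyl group, a methoxy group or a dimethylamino group on the same aromatic carbon would also lower the number remains open. From the compounds shown here alone, the steps among compound 1, compound 2 and compound 3 cannot be read, and their order in this assay remains unknown.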